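A few compounds are considered here, and "the series" means these few. Any claim that something is new, unique, unknown or untested is made for them only; others in the source may bear on it.

Compound 1 `COc1ccc(C2CC(c3ccccc3)=NN2C2=NC(=O)/C(=C3\C(=O)Nc4ccccc43)S2)cc1` gives 4580 nM in a functional assay on cells (Cancer cell lines, Homo sapiens) for cytotoxicity, read by sulforhodamine B assay, with a stated time of 48 h; a lower number here means a stronger inhibitor of growth, a higher number a weaker inhibitor of growth. Compound 2 `COc1ccc(C2CC(c3ccccc3)=NN2C2=NC(=O)/C(=C3\C(=O)Nc4ccc(Br)cc43)S2)cc1` gives 480 nM in this assay. Compound 3 `COc1ccc(C2=NN(C3=NC(=O)/C(=C4\C(=O)Nc5ccccc54)S3)C(c3ccc(OC)cc3)C2)cc1` gives 99600 nM in this assay.

Compound 3 stands at the highest number of the three. Its nearest neighbour is compound 1, reached by a 22-fold higher number from compound 1 to compound 3 (1.34 log units; beyond the scatter); compound 2 lies further off. Compound 4 `COc1ccc(C2=NN(C3=NC(=O)/C(=C4\C(=O)Nc5ccc(Br)cc54)S3)C(c3ccc(OC)cc3)C2)cc1` differs from compound 3 by bromo in place of hydrogen on an aromatic carbon. Within the data shown here, the one measured step that bears on this change is a 9.5-fold lower number from compound 1 to compound 2 (0.98 log units; beyond the scatter), the same bromo for hydrogen exchange on the same ring, made on a core lacking the second methoxy group. A lower number is therefore expected for compound 4 in this assay, a step of about a 10-fold lower number from compound 3 to compound 4 (1.00 log units; beyond the scatter). The estimate for compound 4 is 10000 nM, within a range from 3000 nM to 40000 nM.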

Compound 4, concentration for total growth inhibition: 480 nM
For compound 4 the middle estimate is 21-fold (1.32 log units) above the measured one; measured number outside the range, below it.
By their numbers in this assay, from the lowest: compounds 2 and 4 (each within the scatter of the next); then compound 1; then compound 3.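

In this assay, bromo in place of hydrogen on an aromatic carbon gives a 210-fold lower number from compound 3 to compound 4 (2.32 log units; beyond the scatter), so the size of this change depends on the core that carries it: the same change on two cores in this assay, a 9.5-fold lower number (0.98 log units; beyond the scatter) from compound 1 to compound 2 and a 210-fold lower number (2.32 log units; beyond the scatter) from compound 3 to compound 4, 22-fold (1.34 log units) apart, beyond the scatter of two such steps. A second methoxy group gives a 22-fold higher number from compound 1 to compound 3 (1.34 log units; beyond the scatter) on the core without bromo, yet with bromo present it gives no change at the digits printed from compound 2 to compound 4 (within the scatter), so the two changes do not simply add: the same change on two cores in this assay, a 22-fold higher number (1.34 log units; beyond the scatter) from compound 1 to compound 3 and no change at the digits printed (within the scatter) from compound 2 to compound 4, 22-fold (1.34 log units) apart, beyond the scatter of two such steps.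

The compounds shown leave open whether chloro or an amine on the same aromatic carbon would behave as bromo does. They also leave open whether a longer chain in place of methoxy would leave the number unchanged with bromo present.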